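Ester aryl variation in a urotensin-2 receptor binding series

The source may hold more compounds than are shown below. What is called first, only, known or untested is meant among the compounds shown, and "the series" means these compounds.

Three esters have been measured in an assay on NIH3T3 cells with Urotensin-2 receptor (Homo sapiens) as the target; on this read-out lower numbers stand for an effect already at smaller amounts and higher numbers for an effect only at larger amounts of compound:
compound 1 `CN(C)CCC(OC(=O)c1cn(C)c2ccccc12)c1ccc(Cl)cc1` gives 1510 nM
compound 2 `Cc1ccsc1C(=O)OC(CCN(C)C)c1ccc(Cl)cc1` gives 2510 nM
compound 3 `COc1cccc(C(=O)OC(CCN(C)C)c2ccc(Cl)cc2)c1C` gives 1950 nM

Compound 2 stands at the highest of the three numbers, but its gaps to compound 3 and to compound 1 both lie within the scatter, so the three values do not separate. Compound 4 `Cc1ccc(C)c(C(=O)OC(CCN(C)C)c2ccc(Cl)cc2)c1` differs from compound 2 by 2,5-dimethylphenyl in place of 3-methylthiophen-2-yl on a carbonyl carbon. Among the measured compounds shown here, no step between measured compounds carries this change. Since all three measured aryl esters cluster within the scatter of each other, the step to compound 4 is expected to be small, at most a modest move toward lower numbers, and not beyond the scatter. The step of a 1.4-fold lower number from compound 2 to compound 4 (0.14 log units; within the scatter) is the expected outcome. Compound 4 is estimated at 1800 nM in this assay, expected to fall between 700 nM and 4500 nM.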

Compound 4, half-maximal effective concentration: 1860 nM
Compound 4: middle estimate off by 1.0-fold (0.01 log units), on the low side; the measured number falls inside the stated range.
By their numbers in this assay, from the lowest: compounds 1, 4, 3 and 2 (each within the scatter of the next).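

In this assay, among the compounds shown here, replacing 3-methylthiophen-2-yl with 2,5-dimethylphenyl on a carbonyl carbon gives a 1.3-fold lower number from compound 2 to compound 4 (0.13 log units; within the scatter), the first direct step at this place. A five-membered aromatic ring with 1 hetero atom and a six-membered aromatic ring of carbon only are therefore not separated by this read-out. No supporting measurement bears on this result.

Open, as far as these compounds go, is whether any group at this place moves the number beyond the scatter. A carboxylic acid or an amine on the aryl ring would test this.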